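Trimming the amide chain: expected stability of compound 3

A few compounds are considered here, and "the series" means these few. Any claim that something is new, unique, unknown or untested is made for them only; others in the source may bear on it.

Measured compounds:
compound 1 `Cc1cc(/C=C/C#N)cc(C)c1Oc1cc(Nc2ccc(C#N)cc2)c(N)cc1C(N)=O`: 1.5 h
compound 2 `Cc1cc(/C=C/C#N)cc(C)c1Oc1cc(Nc2ccc(C#N)cc2)c(N)cc1C(=O)NCCC(F)F`: 0.233 h

In an ADME assay on microsomes from liver (Homo sapiens) for metabolic stability, read by LC-MS, using NADPH, with a stated time of 45 min, tested at 1 uM (on this read-out higher numbers stand for a longer-lived compound and lower numbers for a shorter-lived compound), compound 2 gives 0.233 h, the lower of the two numbers; compound 1 gives 1.5 h. Going by the values given here, the only measured step, a 6.4-fold lower number from compound 1 to compound 2 (0.81 log units; beyond the scatter), accompanied 3,3-difluoropropyl in place of hydrogen on the amide nitrogen. Compound 3 `CNC(=O)c1cc(N)c(Nc2ccc(C#N)cc2)cc1Oc1c(C)cc(/C=C/C#N)cc1C` differs from compound 2 by hydrogen in place of 2,2-difluoroethyl on a saturated chain carbon bound to an amide-type nitrogen, which undoes most of that added chain, so a partial reversal toward compound 1 is expected rather than a step the other way. Compound 3 is therefore estimated to give 0.7 h, with a range from 0.3 h to 1.6 h, meaning a 3.0-fold higher number from compound 2 to compound 3 (0.48 log units; beyond the scatter).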

Compound 3, half-life: 1.87 h
The estimate for compound 3 lay 2.7-fold (0.43 log units) below the measured number; measured number outside the range, above it.
By their numbers in this assay, from the lowest: compound 2; then compounds 1 and 3 (each within the scatter of the next).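

In this assay, hydrogen in place of 2,2-difluoroethyl on the saturated chain carbon bound to the amide-type nitrogen gives an 8.0-fold higher number from compound 2 to compound 3 (0.90 log units; beyond the scatter), so the short half-life of compound 2 goes with that outer part of the chain, not with having a substituent on this nitrogen as such. A methyl group alone changes little, with a 1.2-fold higher number from compound 1 to compound 3 (0.10 log units; within the scatter) as the step. No evidence on the cause is at hand. On these data alone, whether chain length or fluorine matters stays open: a plain propyl chain could separate them, and a chain ending in an amine would test another end group.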